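A few compounds are considered here, and "the series" means these few. Any claim that something is new, unique, unknown or untested is made for them only; others in the source may bear on it.

Working notes on the series. Of the compounds shown here, three have been measured in an ADME assay on BJ cells (Homo sapiens) for inhibition, with a stated time of 72 h; a higher number here means that more compound is needed for the effect, a lower number that less compound is needed. Compound 1 `COc1ccc(-c2nc3ccccc3s2)cc1NC(=O)c1cnccc1Cl` returns only a limit of the assay in this assay, > 25000 nM. Compound 2 `Cc1ccc(-c2nc3ccccc3o2)cc1NC(=O)c1cnccc1Cl` also returns only the assay limit, > 25000 nM. Compound 3 `COc1ccc(-c2nc3ccccc3o2)cc1NC(=O)c1cnccc1Cl` likewise stands at the assay limit, > 25000 nM. Compound 3 therefore has no readable position on the numbers: it shares the limit with both of its neighbours. Within the data shown here, the step that the two limits leave unreadable from compound 1 to compound 3 and the step that the two limits leave unreadable from compound 2 to compound 3 are both unreadable in size, and the single piece of evidence across the set is the limit of > 25000 nM in this assay, at which 3 of the 3 values shown sit.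

Compound 4 `O=C(Nc1cc(-c2nc3ccccc3o2)ccc1F)c1cnccc1Cl` has not yet been measured in this assay. It differs from compound 3 by fluoro in place of methoxy on an aromatic carbon. Among the measured compounds shown here, neither measured step concerns a fluoro for methoxy exchange, and neither yields a readable size; together they show only that all three measured compounds remain at the limit whether the core carries 1,3-benzoxazol-2-yl or 1,3-benzothiazol-2-yl, methyl or methoxy. The expectation is accordingly no step beyond the scatter: a step that the limit leaves unreadable from compound 3 to compound 4 is expected, with compound 4 most likely again reported as a limit rather than a number. Compound 4 is estimated at 40000 nM in this assay, within 12000 nM to 150000 nM.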

Compound 4, half-maximal effective concentration: > 25000 nM
Compound 4: no number, only a limit (the forecaster's own chance of this, stated with the estimate: 85%); the middle value lies beyond the limit too.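

Compound 4 again gives only a limit of the assay, so the steps to it from compound 2 and from compound 3 cannot be read in size. The compounds shown leave open whether any compound of this series gives a readable number in this assay, and how far each one lies beyond the limit.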